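Replacing 4-fluorophenyl with 3,5-dimethoxyphenyl in the series

The source may hold more compounds than are shown below. What is called first, only, known or untested is meant among the compounds shown, and "the series" means these compounds.

In an ADME assay on WI-38 cells (Homo sapiens) for cytotoxicity, read by MTT assay, with a stated time of 72 h (on this read-out lower numbers stand for stronger inhibition and higher numbers for weaker inhibition), compound 1 (`C#Cc1cccc(NC(=O)CCc2cccc3c2B(O)OC3)c1`) gives > 100000 nM, which is a limit of the assay and not a number. Among the compounds with values here, compound 2 (`O=C(CCc1cccc2c1B(O)OC2)Nc1cccc(-c2ccc(F)cc2)c1`) gives 4100 nM, the only actual number so far. Compound 3 (`COc1cc(OC)cc(-c2cccc(NC(=O)CCc3cccc4c3B(O)OC4)c2)c1`) carries 3,5-dimethoxyphenyl in place of 4-fluorophenyl on an aromatic carbon. Within the data shown here, the one measured step bears on this only indirectly. It is an at least 24-fold lower number from compound 1 to compound 2 (1.38 log units; beyond the scatter), a large change that put 4-fluorophenyl in place of ethynyl, whereas compound 3 keeps a six-membered aromatic ring of carbon only at that place. A repeat of that size is therefore not expected in this assay, and no shift beyond the scatter is expected. The expected step is a 1.2-fold higher number from compound 2 to compound 3 (0.09 log units; within the scatter). For compound 3 the estimated value is 5000 nM, with an expected range from 1500 nM to 20000 nM.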

Compound 3, half-maximal inhibitory concentration: 1700 nM
Beside the measured number, compound 3's estimate is 2.9-fold (0.47 log units) above it; the measured number falls inside the stated range.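

In this assay, exchanging one six-membered aromatic ring of carbon only for another at this position still moves the read-out: a 2.4-fold lower number from compound 2 to compound 3 (0.38 log units; beyond the scatter). The presence of such a ring therefore does not settle the number on its own; what the ring carries also counts. Against ethynyl the gap widens, with an at least 58-fold lower number from compound 1 to compound 3 (1.76 log units; beyond the scatter), and compound 1 remains a limit of the assay and not a number, so that size is only a floor: the limit of > 100000 nM in this assay, at which 1 of the 3 values shown sits.

Among the compounds shown, it stays open whether the two methoxy groups or the loss of fluorine accounts for the step. An unsubstituted phenyl, or a ring bearing an amine or a carboxylic acid at this place, would help separate these readings.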